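Thiadiazole Cinnamamides: A Fourth Analog Awaits Testing

A few compounds are considered here, and "the series" means these few. Any claim that something is new, unique, unknown or untested is made for them only; others in the source may bear on it.

The measured compounds and their values in a functional assay on MCF7 cells (Homo sapiens) for antiproliferative activity, read by MTT assay, with a stated time of 48 h (on this read-out lower numbers stand for stronger inhibition and higher numbers for weaker inhibition), are:
compound 1, `O=C(/C=C/c1ccccc1)Nc1nnc(-c2ccccc2)s1`, 1.47 ug/mL
compound 2, `O=C(/C=C/c1ccc(F)cc1)Nc1nnc(-c2ccccc2)s1`, 1.45 ug/mL
compound 3, `O=C(/C=C/c1ccc(F)cc1)Nc1nnc(-c2ccc(Cl)cc2)s1`, 1.58 ug/mL

Compound 4, `O=C(/C=C/c1ccccc1)Nc1nnc(-c2ccc(Cl)cc2)s1`, has not yet been measured in this assay. Compound 2 and compound 3 differ in their cores by chloro in place of hydrogen on an aromatic carbon, a change that gave a 1.1-fold higher number from compound 2 to compound 3 (0.04 log units; within the scatter). Compound 4 differs from compound 3 by hydrogen in place of fluoro on an aromatic carbon. The same change was made before, from compound 2 to compound 1, (hydrogen in place of fluoro on an aromatic carbon), and there it gave a 1.0-fold higher number from compound 2 to compound 1 (0.01 log units; within the scatter). Because that step was a 1.0-fold higher number from compound 2 to compound 1 (0.01 log units; within the scatter), the same change on the core of compound 3 is expected to give a step close to a 1.0-fold higher number from compound 3 to compound 4 (0.01 log units; within the scatter). In this assay compound 4 is therefore estimated at 1.6 ug/mL.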

Compound 4, half-maximal inhibitory concentration: 1.42 ug/mL
Compound 4: the middle estimate sits 1.1-fold (0.05 log units) above what was measured, within the range that was stated.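

In this assay, hydrogen in place of fluoro gave a 1.1-fold lower number from compound 3 to compound 4 (0.05 log units; within the scatter), and this step agrees with the earlier one: the same change on two cores in this assay, a 1.0-fold higher number (0.01 log units; within the scatter) from compound 2 to compound 1 and a 1.1-fold lower number (0.05 log units; within the scatter) from compound 3 to compound 4, 1.1-fold (0.05 log units) apart, within the scatter of two such steps. Chloro in place of hydrogen gave a 1.0-fold lower number from compound 1 to compound 4 (0.02 log units; within the scatter), which likewise agrees with its earlier step: the same change on two cores in this assay, a 1.1-fold higher number (0.04 log units; within the scatter) from compound 2 to compound 3 and a 1.0-fold lower number (0.02 log units; within the scatter) from compound 1 to compound 4, 1.1-fold (0.05 log units) apart, within the scatter of two such steps. Across these two pairs of cores, neither change moved the number beyond the scatter, but this does not show that a step of real size would carry from one core to another, nor that the same would hold on other cores.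

The compounds shown leave open what an amine, a methoxy group or a carboxylic acid in place of the fluoro or chloro would do in this assay. They also leave open whether any change to the shared core would move the number.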